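One Group Swapped on an Amide-Type Nitrogen

The source may hold more compounds than are shown below. What is called first, only, known or untested is meant among the compounds shown, and "the series" means these compounds.

Among the compounds with values here, only two compounds have been measured so far, and they share part of their structure. In a physicochemical assay for solubility, at pH 6.8 (on this read-out lower numbers stand for lower solubility and higher numbers for higher solubility), compound 1 (`CCN1CCc2c(ncnc2Oc2ccc3c(ccn3C(=O)Nc3cccc(C(F)(F)F)c3)c2)C1`) reads < 5000 nM, which is a limit of the assay and not a number. Within the data shown here, compound 2 (`Cc1cncc(NC(=O)n2ccc3cc(Oc4ncnc5c4CCNC5)ccc32)c1`) gives 190000 nM, the only actual number available.

Compound 3 (`CC(C)(C)c1cc(NC(=O)n2ccc3cc(Oc4ncnc5c4CCNC5)ccc32)no1`) keeps the core of compound 2 and changes one group, with 5-(tert-butyl)-1,2-oxazol-3-yl in place of 5-methylpyridin-3-yl on an amide-type nitrogen. Among the measured compounds shown here, no two measured compounds differ in one place only, so this forecast is a judgement and not a reading from an earlier step. For the measured compounds named here, the one guide to how low such compounds can go is compound 1, whose < 5000 nM is again only a limit. A clear fall in this assay, larger than the usual scatter, is expected, and the estimated change is a 9.5-fold lower number from compound 2 to compound 3 (0.98 log units; beyond the scatter). For compound 3 the expected value is 20000 nM, with an estimated range from 4000 nM to 90000 nM.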

Compound 3, solubility: 167000 nM
Compound 3: middle estimate off by 8.4-fold (0.92 log units), on the low side; the measured number lies above the stated range.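

In this assay, setting 5-(tert-butyl)-1,2-oxazol-3-yl in place of 5-methylpyridin-3-yl on an amide-type nitrogen gives a 1.1-fold lower number from compound 2 to compound 3 (0.06 log units; within the scatter), so this read-out does not tell the two compounds apart. This is the only one-place step shown, and it is the first direct look at this position: a six-membered aromatic ring gives way to a five-membered aromatic ring carrying a tert-butyl group, with more heavy atoms overall, and the number stays within the scatter. Compound 1 is the one compound recorded as a limit of the assay, whereas the other two compounds have actual numbers, so this step is a comparison of real readings: the limit of < 5000 nM in this assay, at which 1 of the 3 values shown sits.

From the compounds shown here alone, what stays open is whether a group of another kind on this nitrogen, such as a phenyl ring carrying a carboxylic acid or an amine, would move the number beyond the scatter. Compound 1 differs from compound 2 in more than one place, and the compounds shown do not separate the contribution of each of those places.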